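Moving the chlorine on a low-toxicity series

The compounds below may be only part of what the source reports. "The series", "measured", "known", "first", "only" and "open" are said of these compounds alone.

Measured so far:
compound 1 `COc1ccc(Nc2nnnn2-c2ccccc2Cl)cc1` gives 100000 nM
compound 2 `COc1ccc(-n2nnnc2Nc2ccccc2Br)cc1` gives 137000 nM
compound 3 `COc1ccc(-n2nnnc2Nc2ccc(Cl)cc2)cc1` gives 143000 nM

In an ADME assay on HaCaT cells (Homo sapiens) for cytotoxicity, read by MTT assay, with a stated time of 72 h (a higher number here means a weaker inhibitor, a lower number a stronger inhibitor), compound 3 gives 143000 nM and lies within the usual scatter of both other compounds. In compound 4 (`COc1ccc(-n2nnnc2Nc2ccccc2Cl)cc1`) 2-chlorophenyl stands in place of 4-chlorophenyl on a nitrogen on an aromatic ring (2-chlorophenyl in place of 4-chlorophenyl on a nitrogen on an aromatic ring). The two have the same atoms, joined differently. Within the data shown here, one measured step bears on this change: a 1.0-fold higher number from compound 2 to compound 3 (0.02 log units; within the scatter) as 4-chlorophenyl replaces 2-bromophenyl in that place. It stays within the scatter. Compound 1 also carries 2-chlorophenyl and gives 100000 nM in the same range. No step beyond the scatter is therefore expected in this assay and no direction can be called (a 1.1-fold lower number from compound 3 to compound 4 (0.04 log units; within the scatter)). The estimated value for compound 4 is 130000 nM with an expected range from 80000 nM to 200000 nM in this measurement.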

Compound 4, half-maximal inhibitory concentration: 134000 nM
For compound 4 the middle estimate is 1.0-fold (0.01 log units) below the measured one; the range from low to high includes it.
By their numbers in this assay, from the lowest: compounds 1, 4, 2 and 3 (each within the scatter of the next).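

In this assay, moving the chlorine gives a 1.1-fold lower number from compound 3 to compound 4 (0.03 log units; within the scatter), so 2-chlorophenyl and 4-chlorophenyl on this nitrogen cannot be told apart here. Chloro in place of bromo on an aromatic carbon, with the position kept, gives a 1.0-fold lower number from compound 2 to compound 4 (0.01 log units; within the scatter), which also stays within the scatter. Nothing available explains why these changes leave the number so flat. Still open, as far as these compounds go, is whether an amine or a carboxylic acid on this ring would move the number beyond the scatter. Also open, from the compounds shown here alone, is whether a change on the methoxy group would do so.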